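The compounds below may be only part of what the source reports. "The series", "measured", "known", "first", "only" and "open" are said of these compounds alone.

Of the compounds shown here, two have been measured so far. Compound 1 `O=C(CSc1nc(Nc2ccccc2)c2ccccc2n1)Nc1cccc(F)c1` gives 15600 nM in a functional assay on PC-3 cells (Homo sapiens) for inhibition, read by MTT assay, with a stated time of 72 h; a higher number here means a weaker inhibitor, a lower number a stronger inhibitor. Compound 2 `C=CC(=O)Nc1cccc(NC(=O)CSc2nc(Nc3ccccc3Cl)c3ccccc3n2)c1`, which carries an acrylamide on the outer amide ring and a chlorine on the anilino ring, gives 14400 nM in this assay. On these two numbers compound 2 and compound 1 sit within the usual scatter of each other, so nothing can be said about which of the two is the better inhibitor.

Compound 3 `C=CC(=O)Nc1cccc(NC(=O)CSc2nc(Nc3ccc(Br)cc3)c3ccccc3n2)c1` keeps everything in compound 2 except the ring on the anilino nitrogen, where the change is 4-bromophenyl in place of 2-chlorophenyl on a nitrogen on an aromatic ring. Among the compounds with values here, no measured pair in this set shows what such a swap of one halogenated phenyl for another does, so the expectation rests only on the fact that both measured compounds lie close together. The step from compound 2 to compound 3 is therefore expected to be small, a 1.0-fold lower number from compound 2 to compound 3 (0.01 log units; within the scatter), in no particular direction and most likely within the scatter. For compound 3 the estimated result in this assay is 14000 nM, with a plausible range from 5000 nM to 40000 nM.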

Compound 3, half-maximal inhibitory concentration: 12400 nM
Compound 3: middle estimate off by 1.1-fold (0.05 log units), on the high side; low and high end bracket the measured number.
By their numbers in this assay, from the lowest: compounds 3, 2 and 1 (each within the scatter of the next).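

Within the data shown here, compound 2 and compound 3 are the first pair that differ in one place only, and in this assay putting 4-bromophenyl in place of 2-chlorophenyl on a nitrogen on an aromatic ring comes to a 1.2-fold lower number from compound 2 to compound 3 (0.06 log units; within the scatter) and so gives no measurable difference between the two. This position therefore accepts either of these two halogenated phenyl groups with no change that can be told from the scatter, although the halogen and its place on the ring differ at once, so this pair cannot separate those two features. Nothing is available that would explain this result.

The compounds shown leave open what a carboxylic acid or an amine on this phenyl ring would do, or what a longer carbon chain would do on the same nitrogen in place of the ring. They also leave open the share of the acrylamide in these values, since compound 1 differs from compound 2 in more than one place and that pair cannot be read as a single change.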